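Benzyl ether variation and cytotoxicity in a shared-core series

This account rests on a few compounds, and the source may have more. Where it says the series, first, only, none or still open, it means among the compounds named here.

Going by the values given here, in an ADME assay on MT4 cells (Homo sapiens) for cytotoxicity, read by MTT assay, with a stated time of 5 days (on this read-out lower numbers stand for higher toxicity in this test and higher numbers for lower toxicity in this test), compound 2 `N#Cc1ccc(Nc2nccc(OCc3ccccc3Br)n2)cc1` gives 130000 nM, the highest of the three numbers measured so far. Compound 3 `Cc1cccc(COc2ccnc(Nc3ccc(C#N)cc3)n2)c1` gives 30000 nM and compound 1 `N#Cc1ccc(Nc2nccc(OCc3cccnc3)n2)cc1` gives 6400 nM. The steps among them are a 20-fold higher number from compound 1 to compound 2 (1.31 log units; beyond the scatter), a 4.7-fold higher number from compound 1 to compound 3 (0.67 log units; beyond the scatter) and a 4.3-fold lower number from compound 2 to compound 3 (0.64 log units; beyond the scatter). Compound 4 `COc1ccc(COc2ccnc(Nc3ccc(C#N)cc3)n2)cc1` is not yet measured; relative to compound 2 the change is 4-methoxyphenyl in place of 2-bromophenyl on a saturated chain carbon bound to an oxygen on an aromatic ring. The step bearing most directly on it is a 4.3-fold lower number from compound 2 to compound 3 (0.64 log units; beyond the scatter), where one substituted phenyl was exchanged for another and the number fell modestly; the step of a 4.7-fold higher number from compound 1 to compound 3 (0.67 log units; beyond the scatter) shows a substituted phenyl standing above the pyridin-3-yl. A modest lowering is therefore expected, a 3.3-fold lower number from compound 2 to compound 4 (0.51 log units; beyond the scatter). The estimate for compound 4 in this assay is 40000 nM, within 12000 nM to 130000 nM.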

Compound 4, half-maximal cytotoxic concentration: 102000 nM
For compound 4 the middle estimate is 2.6-fold (0.41 log units) below the measured one; low and high end bracket the measured number.
By their numbers in this assay, from the lowest: compound 1; then compound 3; then compounds 4 and 2 (each within the scatter of the next).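

At this position in this assay, 4-methoxyphenyl in place of 2-bromophenyl produces no separable change (a 1.3-fold lower number from compound 2 to compound 4 (0.11 log units; within the scatter)), so exchanging one substituted phenyl for another need not move the number. The modest fall seen with 3-methylphenyl is therefore not shared by every substituted phenyl (a 3.4-fold higher number from compound 3 to compound 4 (0.53 log units; beyond the scatter)), and 4-methoxyphenyl joins 2-bromophenyl in a large step away from pyridin-3-yl (a 16-fold higher number from compound 1 to compound 4 (1.20 log units; beyond the scatter)). No measurement at hand explains these differences. Open, as far as these compounds go, is how a phenyl carrying an amine or a carboxylic acid would read here. Also open, from the compounds shown here alone, is whether a longer chain would preserve these steps.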